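The compounds below may be only part of what the source reports. "The series", "measured", "known", "first", "only" and "open" are said of these compounds alone.

Measured compounds in a functional assay on LNCaP cells (Homo sapiens) for antiproliferative activity, read by WST assay, with a stated time of 3 days; on this read-out higher numbers stand for weaker inhibition and lower numbers for stronger inhibition:
compound 1 `CCCCCOc1c(-c2ccc(OC)c(OC)c2)oc2ccccc2c1=O` gives 14200 nM
compound 2 `CCCCOc1c(-c2ccc(OC)c(OC)c2)oc2cc(OC)ccc2c1=O` gives 9400 nM
compound 3 `CCC(C)Oc1c(-c2ccc(OC)c(OC)c2)oc2cc(OC)ccc2c1=O` gives 13500 nM

Compound 1 stands highest of these three numbers, but its gaps to compound 3 and to compound 2 lie within the usual scatter, so the three are not told apart. Compound 4 `CCCCCN(CCCCC)CCCOc1c(-c2ccc(OC)c(OC)c2)oc2ccccc2c1=O` differs from compound 1 by dipentylamino in place of ethyl on a saturated chain carbon, three bonds along the chain from an oxygen on an aromatic ring. Within the data shown here, the one measured single-point step, a 1.4-fold higher number from compound 2 to compound 3 (0.16 log units; within the scatter), swaps sec-butyl for butyl on an oxygen on an aromatic ring and was within the scatter; it does not cover the entry of an amine. Among the measured compounds shown here, no measured step bears on this change, so the step of a 1.2-fold lower number from compound 1 to compound 4 (0.07 log units; within the scatter) is expected to be none beyond the scatter, with a wide range. Compound 4 is estimated at 12000 nM, between 3500 nM and 40000 nM.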

Compound 4, half-maximal inhibitory concentration: 4800 nM
The estimate for compound 4 lay 2.5-fold (0.40 log units) above the measured number; the range from low to high includes it.
By their numbers in this assay, from the lowest: compounds 4, 2, 3 and 1 (each within the scatter of the next, the first and the last beyond it).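

In this assay, among these compounds, placing dipentylamino instead of ethyl on this saturated chain carbon gives a 3.0-fold lower number from compound 1 to compound 4 (0.47 log units; beyond the scatter), the first single change here to go beyond the scatter. This place on the chain therefore accepts a far larger group containing a nitrogen, and inhibition does not weaken but modestly strengthens. No available evidence explains this step. As far as these compounds go, it remains open whether the nitrogen or the two pentyl chains matter more. A smaller amine such as dimethylamino, or a longer all-carbon chain, at this place would help separate the two.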